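Morpholine amide on the methylpyridine series

The compounds below may be only part of what the source reports. "The series", "measured", "known", "first", "only" and "open" are said of these compounds alone.

Measured compounds:
compound 1, `CCC(CC)[C@@H]1C(=O)N[C@H](C2Cc3ccccc3C2)C(=O)N1[C@@H](C(=O)N1CCOCC1)c1ccc(C)nc1`, 0.0251 nM
compound 2, `CCC(CC)[C@@H]1C(=O)N[C@H](C2Cc3ccccc3C2)C(=O)N1[C@@H](C(=O)NC)c1ccc(C)nc1C`, 0.0501 nM
compound 3, `CC[C@H](C)[C@@H]1C(=O)N[C@H](C2Cc3ccccc3C2)C(=O)N1[C@@H](C(=O)NC)c1cc(C)cnc1C`, 1.26 nM

In an assay on isolated protein for displacement of a labelled ligand from Oxytocin receptor (Homo sapiens) (on this read-out lower numbers stand for stronger inhibition and higher numbers for weaker inhibition), compound 2 stands second highest of the three numbers. Its nearest neighbour is compound 1, whose number is lower but within the usual scatter, so no order between the two can be claimed. Compound 3 lies furthest away, with a markedly higher number that is beyond the scatter; compound 3 also differs from compound 2 in more than one place, so no single step accounts for it.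

Compound 4, `CCC(CC)[C@@H]1C(=O)N[C@H](C2Cc3ccccc3C2)C(=O)N1[C@@H](C(=O)N1CCOCC1)c1ccc(C)nc1C`, has not yet been measured. It differs from compound 2 in one place: morpholin-4-yl in place of methylamino on a carbonyl carbon. The same change is already present on compound 1, which carries the morpholine amide and gives 0.0251 nM in this assay, a number within the scatter of compound 2. On that basis the expected step of a 1.7-fold lower number from compound 2 to compound 4 (0.22 log units; within the scatter) is none beyond the scatter, with perhaps a slight lean towards a lower number. Compound 4 is therefore estimated at 0.03 nM, with a range from 0.01 nM to 0.1 nM.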

Compound 4, inhibition constant: 0.0316 nM
Beside the measured number, compound 4's estimate is 1.1-fold (0.02 log units) below it; low and high end bracket the measured number.
By their numbers in this assay, from the lowest: compounds 1, 4 and 2 (each within the scatter of the next); then compound 3.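

In this assay, morpholin-4-yl in place of methylamino on a carbonyl carbon gives a 1.6-fold lower number from compound 2 to compound 4 (0.20 log units; within the scatter), so this position takes on a six-membered ring and loses the amide hydrogen without the read-out separating the two compounds. Methyl in place of hydrogen on an aromatic carbon gives a 1.3-fold higher number from compound 1 to compound 4 (0.10 log units; within the scatter), so with the morpholine amide in place this methyl also leaves the two compounds unseparated. No measurement shown here offers an explanation for either step.

Going by these compounds, it remains open whether a piperidine amide or a dimethylamino group on the same carbonyl carbon, or a carboxylic acid there, would stay as close to these compounds. Also open, on these data alone, is whether morpholin-4-yl gives an equally small step on the core of compound 3.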